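A few compounds are considered here, and "the series" means these few. Any claim that something is new, unique, unknown or untested is made for them only; others in the source may bear on it.

Compound 1 `CC1=C(C(=O)Nc2ccc(F)c(Cl)c2)C(c2ccccc2Cl)NC(=S)N1`, compound 2 `CC1=C(C(=O)Nc2ccc(F)c(Cl)c2)C(c2cccc(Oc3ccccc3)c2)NC(=S)N1` and compound 3 `CC1=C(C(=O)Nc2ccc(Cl)c(Cl)c2)C(c2cccc(Oc3ccccc3)c2)NC(=S)N1` were all tested in a functional assay on SF-268 cells (Homo sapiens) for cytotoxicity, read by sulforhodamine B assay, with a stated time of 48 h; a lower number here means a stronger inhibitor of growth, a higher number a weaker inhibitor of growth. Compound 1 gives 14800 nM, compound 2 gives 8910 nM and compound 3 gives 6170 nM. Compound 2 and compound 3 differ in one place, (chloro in place of fluoro on an aromatic carbon), and that change made a 1.4-fold lower number from compound 2 to compound 3 (0.16 log units; within the scatter). Compound 1 and compound 2 share the thiourea-containing core but carry different groups on it, and the difference between the two cores is not broken down here. The new compound, compound 4 `CC1=C(C(=O)Nc2ccc(Cl)c(Cl)c2)C(c2ccccc2Cl)NC(=S)N1`, is built from compound 1 by the same change, (chloro in place of fluoro on an aromatic carbon), with the surroundings of the changed position the same in both pairs. Since the earlier step from compound 2 to compound 3 stayed within the usual scatter, a step of similar size is expected from compound 1 to compound 4, namely a 1.4-fold lower number from compound 1 to compound 4 (0.15 log units; within the scatter), resting only on that one precedent. Compound 4 is therefore estimated to give 10500 nM in this assay, with a plausible range from 5000 nM to 22000 nM.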

Compound 4, concentration for 50% growth inhibition: 8910 nM
Compound 4: the middle estimate sits 1.2-fold (0.07 log units) above what was measured, and the stated range covers the measured number.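

In this assay, turning the 3-chloro-4-fluorophenyl group into a 3,4-dichlorophenyl group gives a 1.7-fold lower number from compound 1 to compound 4 (0.22 log units; within the scatter). Set beside the same change on the other core, the two steps agree: the same change on two cores in this assay, a 1.4-fold lower number (0.16 log units; within the scatter) from compound 2 to compound 3 and a 1.7-fold lower number (0.22 log units; within the scatter) from compound 1 to compound 4, 1.2-fold (0.06 log units) apart, within the scatter of two such steps. Among these compounds, this shows that, on these two cores, swapping fluoro for chloro at this position gives a step too small to separate from repeat-measurement noise, but with both steps inside the scatter and only two pairs, it does not show that chloro truly improves growth inhibition, nor that the change would behave the same way on any other core.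

The compounds shown leave open what happens on this aromatic carbon with a group other than fluoro or chloro, such as bromo, methoxy, trifluoromethyl or an amine, any of which might produce a step large enough to read. They also leave open what a carbonyl would do in place of the thiocarbonyl of the shared core.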